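A few compounds are considered here, and "the series" means these few. Any claim that something is new, unique, unknown or untested is made for them only; others in the source may bear on it.

Measured compounds:
compound 1 `CCCCCCCCn1c(N)c(N)c(=O)[nH]c1=O`: 620 nM
compound 2 `CCCCCCCCCCn1c(N)c(N)c(=O)[nH]c1=O`: 280 nM
compound 3 `CCCCCCCCCCCCn1c(N)c(N)c(=O)[nH]c1=O`: 270 nM

In a functional assay (mitochondria, heart) with Bos taurus as the target (on this read-out higher numbers stand for weaker inhibition and lower numbers for stronger inhibition), compound 3 holds the lowest of the three numbers, but its neighbour compound 2 sits within the scatter of it, so the two cannot be ordered; only compound 1 stands apart, with a higher number beyond the scatter. The measured steps all concern the saturated chain on the aromatic nitrogen: a 2.2-fold lower number from compound 1 to compound 2 (0.35 log units; beyond the scatter) and a 2.3-fold lower number from compound 1 to compound 3 (0.36 log units; beyond the scatter) are modest gains, while a 1.0-fold lower number from compound 2 to compound 3 (0.02 log units; within the scatter) is flat.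

Compound 4 `CCCCCCCCCCCCn1c(N)c(N)c(=O)n(C)c1=O` differs from compound 3 by methyl in place of hydrogen on an aromatic nitrogen. For the measured compounds named here, no measured step touches this aromatic nitrogen or the hydrogen on it; the three steps so far vary the chain only and give no guide to the size or direction of this change. The estimate for compound 4 therefore rests on compound 3 alone and carries a wide range. The step expected is a 1.9-fold higher number from compound 3 to compound 4 (0.27 log units; within the scatter), a shift that may well fall within the scatter but is left open toward a weaker result. Compound 4 is expected to give about 500 nM in this assay, with a range from 150 nM to 3000 nM.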

Compound 4, half-maximal inhibitory concentration: 240 nM
Compound 4: the middle estimate sits 2.1-fold (0.32 log units) above what was measured; measured number inside the range.
By their numbers in this assay, from the lowest: compounds 4, 3 and 2 (each within the scatter of the next); then compound 1.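

In this assay, for the compounds shown here, a 1.1-fold lower number from compound 3 to compound 4 (0.05 log units; within the scatter) is the first step away from the chain, and it stays within the scatter, so methyl on this aromatic nitrogen leaves the read-out indistinguishable from that of compound 3. With the chain of compound 3 in place, the hydrogen on this nitrogen is therefore not required for inhibition on this read-out, and one added carbon is accepted at a position ortho to two groups of 1 heavy atom each. Nothing available bears on why this position accepts the methyl group.

Going by these compounds alone, the single pair leaves open whether the same replacement would read alike on the shorter chain of compound 1, where the number stands apart from those of the longer-chain compounds. It also leaves open how far this nitrogen accepts anything beyond methyl, such as an ethyl, a benzyl or a carboxylic acid-bearing chain, and whether either amino group of the shared core can be replaced in the same way, for instance by an acetamide.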